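The source may report more compounds than this note shows. Statements on the series, on what has been measured and on what is new or still open speak of the compounds shown alone.

Compound 3 `O=C(c1ccc2c(c1)OCCO2)N1N=C(c2ccc(Br)cc2)CC1c1cccc(F)c1` carries a 2,3-dihydro-1,4-benzodioxin-6-yl group on the carbonyl carbon and in a functional assay on WM 266-4 cells (Homo sapiens) for inhibition, read by MTT assay, with a stated time of 24 h (a lower number here means a stronger inhibitor of growth, a higher number a weaker inhibitor of growth), compound 3 gives 810 nM. Compound 1 `O=C(C1COc2ccccc2O1)N1N=C(c2ccc(Br)cc2)CC1c1cccc(F)c1` differs from it only by the change (2,3-dihydro-1,4-benzodioxin-2-yl in place of 2,3-dihydro-1,4-benzodioxin-6-yl on a carbonyl carbon), and in this assay compound 1 gives 7810 nM, so the step of a 9.6-fold higher number from compound 3 to compound 1 (0.98 log units; beyond the scatter) marks a clear weakening within this pair. Compound 2 `COc1ccc(C2CC(c3ccccc3)=NN2C(=O)c2ccc3c(c2)OCCO3)cc1` shares the 2,3-dihydro-1,4-benzodioxin-6-yl group of compound 3 on a different core; the difference between the two cores is not broken down here. In this assay compound 2 gives 8370 nM, and its number lies within the scatter of that of compound 1. Compound 4 `COc1ccc(C2CC(c3ccccc3)=NN2C(=O)C2COc3ccccc3O2)cc1` has not yet been measured; it stands to compound 2 as compound 1 stands to compound 3, through the same change 2,3-dihydro-1,4-benzodioxin-2-yl in place of 2,3-dihydro-1,4-benzodioxin-6-yl on a carbonyl carbon at the same kind of place. For the measured compounds named here, the expected step of a 7.2-fold higher number from compound 2 to compound 4 (0.86 log units; beyond the scatter) for compound 4 rests on the single earlier step of a 9.6-fold higher number from compound 3 to compound 1 (0.98 log units; beyond the scatter) and is expected to be of similar size, with wide uncertainty. Compound 4 is therefore estimated at 60000 nM, between 15000 nM and 200000 nM.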

Compound 4, concentration for 50% growth inhibition: 5080 nM
For compound 4 the middle estimate is 12-fold (1.07 log units) above the measured one, outside the stated range (below it).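

In this assay, putting the 2,3-dihydro-1,4-benzodioxin-2-yl group in place of the 2,3-dihydro-1,4-benzodioxin-6-yl group on the carbonyl carbon gives a 1.6-fold lower number from compound 2 to compound 4 (0.22 log units; within the scatter), so on this core the change has no effect that can be told from the scatter. Set beside the earlier pair, the change does not carry over from one core to the other: the same change on two cores in this assay, a 9.6-fold higher number (0.98 log units; beyond the scatter) from compound 3 to compound 1 and a 1.6-fold lower number (0.22 log units; within the scatter) from compound 2 to compound 4, 16-fold (1.20 log units) apart, beyond the scatter of two such steps. This shows that the weakening seen from compound 3 to compound 1 cannot be treated as a general result of the change in this series, but two pairs do not show which part of the cores decides the outcome, or how the change would behave on a further core.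

The compounds shown leave open which of the differences between the two cores matters, as the bromo, fluoro and methoxy groups are never varied one at a time. They also leave open how the change would behave on a core bearing an amine or a carboxylic acid.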